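Trifluoromethoxy in place of phenol on the aryl group

This account rests on a few compounds, and the source may have more. Where it says the series, first, only, none or still open, it means among the compounds named here.

Measured so far in a functional assay on CHO cells for inhibition of metabotropic glutamate receptor 5 (Rattus norvegicus), read by FLIPR and calcium flux; on this read-out higher numbers stand for weaker inhibition and lower numbers for stronger inhibition:
compound 1 `Cc1ccc2ccc(-c3cccc(CO)c3)cc2n1`: 8700 nM
compound 2 `Cc1ccc2ccc(-c3cccc(O)c3)cc2n1`: 19000 nM

For the measured compounds named here, compound 2 gives the higher of the two numbers; its only neighbour is compound 1, the step being a 2.2-fold higher number from compound 1 to compound 2 (0.34 log units; beyond the scatter) for hydroxy in place of hydroxymethyl. Compound 3 `Cc1ccc2ccc(-c3cccc(OC(F)(F)F)c3)cc2n1` carries trifluoromethyl in place of hydrogen on an oxygen on an aromatic ring. Going by the values given here, no measured step shows this exchange; the single known step, a 2.2-fold higher number from compound 1 to compound 2 (0.34 log units; beyond the scatter), is a different change and only modest in size, so the direction for compound 3 rests on weak ground. A somewhat lower number is expected, a 3.2-fold lower number from compound 2 to compound 3 (0.50 log units; beyond the scatter). Compound 3 is estimated at 6000 nM, within a range from 1500 nM to 25000 nM.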

Compound 3, half-maximal inhibitory concentration: > 10000 nM
Compound 3 ended at the assay's limit; the forecaster's own chance of this, stated with the estimate: 10%; middle value at least 1.6-fold (0.22 log units) away from the limit.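

In this assay compound 3 gives > 10000 nM, which is a limit of the assay and not a number. For the compounds shown here, the step from hydroxy to trifluoromethoxy cannot be read, and the only readable step is an at least 1.1-fold higher number from compound 1 to compound 3 (0.06 log units; that floor lies within the scatter), so trifluoromethoxy in place of hydroxymethyl shows no change separable from the scatter. This position now carries a group whose reading gives only a limit: the limit of > 10000 nM in this assay, at which 1 of the 3 values shown sits.

Still open, as far as these compounds go, is how an amine or a carboxylic acid would read on the same aromatic carbon. From the compounds shown here alone, a longer chain ending in hydroxy is equally open.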